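Selenium for amino on a fused diazine core

The source may report more compounds than this note shows. Statements on the series, on what has been measured and on what is new or still open speak of the compounds shown alone.

Compound 1, `CCCCC[Se]c1nc(N)c2ccccc2n1`, gives 43600 nM in an ADME assay on 184B5 cells (Homo sapiens) for cytotoxicity, read by MTT assay, with a stated time of 72 h; a higher number here means a weaker inhibitor of growth, a lower number a stronger inhibitor of growth.
Compound 2, `COc1ccc(CNc2nc(SC)nc3ccccc23)cc1`, reaches in this assay only a limit, > 100000 nM.
Compound 3, `Nc1nc([SeH])nc2ncccc12`, gives 31100 nM in this assay.

Within the data shown here, only two numbers exist in this assay, and compound 3 and compound 1 lie within the usual scatter of each other, so neither can be set above the other. For compound 2 the value is a limit of the assay and not a number (the limit of > 100000 nM in this assay, at which 1 of the 3 values shown sits), so it adds no ranking.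

The step from compound 3 to compound 4 is read from the two structures: one selenium atom in place of one nitrogen atom, on an aromatic carbon. Compound 4 is `[SeH]c1nc([SeH])c2cccnc2n1` and has not yet been measured in this assay. Among the measured compounds shown here, no step between measured compounds is available, so the size of the change cannot be read from a precedent; both measured numbers sit in a narrow band, and nothing in the data points one way or the other.

The expectation is therefore a modest move at most: compound 4 is estimated at 40000 nM, within 15000 nM to 100000 nM, meaning an expected step of a 1.3-fold higher number from compound 3 to compound 4 (0.11 log units; within the scatter), which stays near the scatter.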

Compound 4, concentration for total growth inhibition: 8260 nM
Compound 4: middle estimate off by 4.8-fold (0.69 log units), on the high side; measured number below the stated range.
By their numbers in this assay, from the lowest: compound 4; then compounds 3 and 1 (each within the scatter of the next). At a limit, above all of these: compound 2.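

In this assay, among these compounds, putting selenium in place of the amino on this aromatic carbon gives a 3.8-fold lower number from compound 3 to compound 4 (0.58 log units; beyond the scatter), the first step that separates two compounds, since the earlier numbers could not be told apart. It shows that this position, next to the ring nitrogen and ortho to a fused ring, responds to the change, and that the amino group is not needed here for growth inhibition: compound 4, which carries selenium at both substituted ring carbons, is the stronger inhibitor of growth of this pair. The measured data give no information on why the number falls, and this rests on a single pair in a single assay.

Going by these compounds, it remains open whether the lower number follows from the entry of selenium or from the departure of the amino, a question that a thiol or a hydroxyl at the same position would help to settle. Also open, on these data alone, is whether the step would hold on the core of compound 1 or with a longer chain on the selenium, such as a methyl or butyl group in place of the hydrogen.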